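Para substituent swap on the triazole-linked aryl ring

A few compounds are considered here, and "the series" means these few. Any claim that something is new, unique, unknown or untested is made for them only; others in the source may bear on it.

For the measured compounds named here, compound 2 `Cc1ccccc1-n1cc(CNC(=O)c2cccc3c2cnn3C(C)C)nn1` gives 19200 nM in a functional assay on PC-3 cells (Homo sapiens) for inhibition, read by MTT assay, with a stated time of 72 h (on this read-out lower numbers stand for stronger inhibition and higher numbers for weaker inhibition), the highest of the two numbers measured so far. Its nearest neighbour is compound 1 `Cc1ccc(-n2cc(CNC(=O)c3cccc4c3cnn4C(C)C)nn2)c(C)c1`, which gives 10600 nM in this assay; the step of a 1.8-fold higher number from compound 1 to compound 2 (0.26 log units; within the scatter) corresponds to hydrogen in place of methyl on an aromatic carbon. Compound 3 `CCc1ccc(-n2cc(CNC(=O)c3cccc4c3cnn4C(C)C)nn2)cc1` has not been measured; it differs from compound 2 by 4-ethylphenyl in place of 2-methylphenyl on an aromatic nitrogen. Going by the values given here, the only measured step that bears on this change is a 1.8-fold higher number from compound 1 to compound 2 (0.26 log units; within the scatter), which concerns a substituent on the same aryl ring and lies within the scatter. Among the compounds with values here, no measured pair tells what removing the 2-methyl group does, and no measured pair carries an ethyl group. On this basis the step from compound 2 to compound 3 is expected to be a 1.5-fold lower number from compound 2 to compound 3 (0.17 log units; within the scatter), a shift no larger than the scatter and, if anything, toward a lower number given the step of a 1.8-fold higher number from compound 1 to compound 2 (0.26 log units; within the scatter) in the reverse sense. Compound 3 is therefore estimated at 13000 nM in this assay, with a range of 5000 nM to 35000 nM.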

Compound 3, half-maximal inhibitory concentration: 26600 nM
The estimate for compound 3 lay 2.0-fold (0.31 log units) below the measured number, and the stated range covers the measured number.
By their numbers in this assay, from the lowest: compounds 1, 2 and 3 (each within the scatter of the next, the first and the last beyond it).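

The swap to 4-ethylphenyl in place of 2-methylphenyl on the aromatic nitrogen (a 1.4-fold higher number from compound 2 to compound 3 (0.14 log units; within the scatter)) leaves these two aryl groups indistinguishable in this assay. For the compounds shown here, the comparison of 4-ethylphenyl with 2,4-dimethylphenyl (a 2.5-fold higher number from compound 1 to compound 3 (0.40 log units; beyond the scatter)) gives the first step beyond the scatter, so the aryl group at this position can shift the number, though only modestly across these three compounds. Nothing available bears on why either step has the size it has.

Compound 3 differs from compound 2 in both the chain and its place on the ring, so the contribution of the 4-ethyl group cannot be separated from the loss of the 2-methyl group. The compounds shown carry only hydrocarbon groups on this aryl ring, which leaves open whether a carboxylic acid, an amine or a longer chain there would move the number further in either direction in this assay.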